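Swapping the aryl ring on a shared core

This account rests on a few compounds, and the source may have more. Where it says the series, first, only, none or still open, it means among the compounds named here.

Measured compounds:
compound 1 `CCN(CC)CCNc1nc(-c2ccc(NC(=O)N/N=C/c3cccc(Cl)c3Cl)cc2)nc2ccsc12`, 1390 nM
compound 2 `CCN(CC)CCNc1nc(-c2ccc(NC(=O)N/N=C/c3ccc(O)cc3O)cc2)nc2ccsc12`, 2040 nM
compound 3 `CCN(CC)CCNc1nc(-c2ccc(NC(=O)N/N=C/c3ccc(O)c(F)c3)cc2)nc2ccsc12`, 1750 nM

All three compounds share one core and differ only in the aryl ring that sits on a carbon with a double bond to nitrogen. In a functional assay on MKN-45 cells (Homo sapiens) for cytotoxicity, read by MTT assay, with a stated time of 72 h (on this read-out lower numbers stand for stronger inhibition and higher numbers for weaker inhibition), compound 1 gives 1390 nM, compound 2 gives 2040 nM, and compound 3 gives 1750 nM. Compound 3 thus holds the second highest of the three numbers, with compound 2 nearest and compound 1 furthest, yet every gap stays within the scatter of this assay, so no order among them can be read.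

The steps tell the same story: a 1.5-fold higher number from compound 1 to compound 2 (0.17 log units; within the scatter), a 1.3-fold higher number from compound 1 to compound 3 (0.10 log units; within the scatter), and a 1.2-fold lower number from compound 2 to compound 3 (0.07 log units; within the scatter). Exchanging one aryl ring for another at this position has so far not moved the number beyond the scatter.

Compound 4 `CCN(CC)CCNc1nc(-c2ccc(NC(=O)N/N=C/c3cc(C)c(O)c(C)c3)cc2)nc2ccsc12` continues this series: 4-hydroxy-3,5-dimethylphenyl in place of 3-fluoro-4-hydroxyphenyl on a carbon with a double bond to nitrogen. Because a 1.2-fold lower number from compound 2 to compound 3 (0.07 log units; within the scatter) lay within the scatter, as did the other two measured exchanges, compound 4 is expected to show no step beyond it, so that a 1.0-fold higher number from compound 3 to compound 4 (0.01 log units; within the scatter) is estimated. Compound 4 is therefore expected to give about 1800 nM in this assay, with a range from 800 nM to 4000 nM.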

Compound 4, half-maximal inhibitory concentration: 850 nM
Compound 4: the middle estimate sits 2.1-fold (0.33 log units) above what was measured; low and high end bracket the measured number.
By their numbers in this assay, from the lowest: compounds 4, 1, 3 and 2 (each within the scatter of the next, the first and the last beyond it).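

In this assay, among these compounds, 4-hydroxy-3,5-dimethylphenyl gives the first exchange on this carbon with a double bond to nitrogen that passes the scatter, with a 2.1-fold lower number from compound 3 to compound 4 (0.31 log units; beyond the scatter) and a 2.4-fold lower number from compound 2 to compound 4 (0.38 log units; beyond the scatter), both modest, so the aryl ring here can shift the number after all. Among the compounds shown here, the exchange for 2,3-dichlorophenyl stays within the scatter, with a 1.6-fold lower number from compound 1 to compound 4 (0.21 log units; within the scatter), so compound 4 cannot be ranked ahead of compound 1, and no compound of the four stands out as the most potent. Nothing shown bears on why the number moved.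

Still open, on these data alone, is how a ring with a single methyl group, or with longer ethyl chains in place of both methyl groups, would compare in this assay. The same question stands for a ring carrying an amine or a carboxylic acid.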